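Adding allyl to the most potent compound

This account rests on a few compounds, and the source may have more. Where it says the series, first, only, none or still open, it means among the compounds named here.

compound 1 `COc1cccc2[nH]c(=O)c(=O)oc12` gives 7000 nM
compound 2 `COc1ccc2[nH]c(=O)c(=O)oc2c1` gives 28000 nM
compound 3 `O=c1[nH]c2ccc(O)cc2oc1=O` gives 170000 nM

In a functional assay with Rattus norvegicus as the target (a lower number here means a stronger inhibitor, a higher number a weaker inhibitor), compound 1 gives 7000 nM as its value, the lowest of the three numbers, which makes it the strongest inhibitor measured so far. Compound 4 `C=CCc1cc(OC)c2oc(=O)c(=O)[nH]c2c1` has not yet been measured. It keeps the core of compound 1 and carries allyl in place of hydrogen on an aromatic carbon, meta to a methoxy group.

Within the data shown here, no measured step makes this exact change. The nearest guide is a 6.1-fold higher number from compound 2 to compound 3 (0.78 log units; beyond the scatter) when hydrogen replaces methyl on an oxygen on an aromatic ring. That modest step involves an oxygen rather than a carbon, so it offers only a weak hint that adding carbon could lower the number. In this assay a small downward step is therefore expected, possibly none beyond the scatter. The expected change is a 1.4-fold lower number from compound 1 to compound 4 (0.15 log units; within the scatter) in this estimate. For compound 4 the estimated value is 5000 nM with a range from 1200 nM to 25000 nM as the expected span.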

Compound 4, half-maximal inhibitory concentration: 10000 nM
For compound 4 the middle estimate is 2.0-fold (0.30 log units) below the measured one; the range from low to high includes it.
By their numbers in this assay, from the lowest: compounds 1 and 4 (each within the scatter of the next); then compound 2; then compound 3.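

In this assay, the step with allyl in place of hydrogen on this aromatic carbon is a 1.4-fold higher number from compound 1 to compound 4 (0.15 log units; within the scatter), so compound 1 and compound 4 cannot be told apart, and this position carries a chain of this size without a clear loss or gain. Among these compounds, the only earlier step concerned a group on an oxygen, so this is the only reading here of a carbon chain placed directly on the aromatic ring. Nothing measured here bears on what lies behind this result.

Allyl is the only group shown at this carbon, so it remains open whether propyl, a longer chain, an amine or a carboxylic acid would be accepted equally well. Also open, on these data alone, is whether allyl would give the same result with a hydroxy group in place of the methoxy group.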